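Mirror-Image Centre on a Nicotinic Receptor Binder

The source may hold more compounds than are shown below. What is called first, only, known or untested is meant among the compounds shown, and "the series" means these compounds.

Compound 2 `c1ccc(COc2cccc(-c3cn([C@@H]4CN5CCC4CC5)nn3)c2)cc1` gives 6.67 nM in an assay on HEK293 cells for displacement of a labelled ligand from Neuronal acetylcholine receptor; alpha3/beta4 (Homo sapiens), read by scintillation counting, with a stated time of 120 min (a lower number here means a stronger inhibitor, a higher number a weaker inhibitor), the higher of the two numbers measured; compound 1 `Fc1cccc(-c2cn([C@@H]3CN4CCC3CC4)nn2)c1` gives 2.25 nM, and the step of a 3.0-fold higher number from compound 1 to compound 2 (0.47 log units; beyond the scatter) comes from benzyloxy in place of fluoro on an aromatic carbon. Compound 3 `c1ccc(COc2cccc(-c3cn([C@H]4CN5CCC4CC5)nn3)c2)cc1` differs from compound 2 only by the two compounds have the same atoms and bonds; at least one stereo element is drawn with a configuration in one of them and without one in the other: 1 of 3 stereo elements differ; a stereocentre at a saturated ring carbon is drawn S in compound 2 and R in compound 3. No measured step alters a stereocentre, so nothing shown guides this change, and the uncertainty is wide. Compound 3 is expected to give 40 nM in this assay. The expected step is a 6.0-fold higher number from compound 2 to compound 3 (0.78 log units; beyond the scatter). The expected range for compound 3 runs from 5 nM to 400 nM.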

Compound 3, inhibition constant: 631 nM
Beside the measured number, compound 3's estimate is 16-fold (1.20 log units) below it; measured number above the stated range.
By their numbers in this assay, from the lowest: compound 1; then compound 2; then compound 3.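

Turning the saturated ring carbon from S to R, with all atoms and bonds kept, gives a 95-fold higher number from compound 2 to compound 3 (1.98 log units; beyond the scatter) in this assay. That is a far larger move than the swap on the aromatic carbon, a 3.0-fold higher number from compound 1 to compound 2 (0.47 log units; beyond the scatter), so among the changes shown, this centre shifts the number most. One caution applies to reading this as a clean swap of configuration: the fact that one of compounds 2 and 3 is drawn with a defined configuration and the other without, at the place where they differ

Going by these compounds, whether a gap of this size between S and R holds with the fluoro group of compound 1, or with an amine or a carboxylic acid on the aromatic ring, stays open.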